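This account rests on a few compounds, and the source may have more. Where it says the series, first, only, none or still open, it means among the compounds named here.

Within the data shown here, in a physicochemical assay for solubility, read by HPLC, with a stated time of 24 h (a higher number here means a more soluble compound, a lower number a less soluble compound), compound 1 `COC(=O)CC1CCN(C[C@H]2CN(c3ccc(-n4cc(-c5ccccn5)cn4)c(F)c3)C(=O)O2)CC1` gives 92100 nM, while compound 2 `O=C1O[C@@H](CSc2cccs2)CN1c1ccc(-n2cc(-c3ccccn3)cn2)c(F)c1` gives 8500 nM, the lower of the two numbers so far. Among the measured compounds shown here, the only measured step, an 11-fold lower number from compound 1 to compound 2 (1.03 log units; beyond the scatter), is large and beyond the scatter. It falls at the same place as the next change, with (thiophen-2-yl)sulfanyl in place of 4-((methoxycarbonyl)methyl)piperidin-1-yl. Compound 3 `CN(C)S(=O)(=O)NC[C@H]1CN(c2ccc(-n3cc(-c4ccccn4)cn3)c(F)c2)C(=O)O1` replaces that (thiophen-2-yl)sulfanyl on a saturated chain carbon bound to a saturated ring carbon: (dimethylsulfamoyl)amino in place of (thiophen-2-yl)sulfanyl on a saturated chain carbon bound to a saturated ring carbon. The entering (dimethylsulfamoyl)amino has no ring. With one step to go on, the expectation rests on the reach of an 11-fold lower number from compound 1 to compound 2 (1.03 log units; beyond the scatter), and a move back toward a higher number seems likely, though probably a smaller one. The expected step is a 3.3-fold higher number from compound 2 to compound 3 (0.52 log units; beyond the scatter). For compound 3 the estimate is 28000 nM, with an expected range of 8000 nM to 95000 nM.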

Compound 3, solubility: 472000 nM
Estimate against measurement, compound 3: 17-fold (1.23 log units) below; the measured number lies above the stated range.
By their numbers in this assay, from the lowest: compound 2; then compound 1; then compound 3.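

At this position, on a saturated chain carbon bound to a saturated ring carbon, the range in this assay proves wider than the first step showed: (dimethylsulfamoyl)amino in place of (thiophen-2-yl)sulfanyl gives a large step (a 56-fold higher number from compound 2 to compound 3 (1.74 log units; beyond the scatter)), which carries the number past that of compound 1 instead of merely recovering the earlier loss. Among these compounds, the step from the piperidine group is modest (a 5.1-fold higher number from compound 1 to compound 3 (0.71 log units; beyond the scatter)), and it places the only group here with no ring at the top of the three compounds. Nothing available accounts for the size of either step.

Open, on these data alone, is whether a methanesulfonylamino group, an acetylamino group or a primary amine at the same place would stay near compound 3. Also open, as far as these compounds go, is what the two methyl groups on the sulfamoyl nitrogen contribute.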